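Swapping the Carboxy Group of Compound 1 for 2-Hydroxyethyl

The source may hold more compounds than are shown below. What is called first, only, known or untested is meant among the compounds shown, and "the series" means these compounds.

Compound 1 `CC(C)(C)[Si](C)(C)O[C@@H]1CCCO[C@@H]1COCC(=O)O` was tested in a functional assay on SW1573 cells (Homo sapiens) for antiproliferative activity, read by sulforhodamine B assay, with a stated time of 48 h; a lower number here means a stronger inhibitor of growth, a higher number a weaker inhibitor of growth. Compound 1 gives > 100000 nM, which is a limit of the assay and not a number. Compound 3 `O=C1COC[C@H]2OCCC[C@@H]2O1` gives > 100000 nM, which is also a limit. Compound 1 thus stands at the limit of > 100000 nM in this assay, at which 2 of the 3 values shown sit. Compound 2 `CC(C)(C)[Si](C)(C)O[C@@H]1CCCO[C@@H]1COCC(=O)OCc1ccccc1` gives a true number, 29000 nM.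

Compound 4 `CC(C)(C)[Si](C)(C)O[C@@H]1CCCO[C@@H]1COCCCO` has not yet been measured. It carries 2-hydroxyethyl in place of carboxy on a saturated chain carbon bound to an oxygen on a saturated carbon.

Going by the values given here, only one measured step bears on this change: an at least 3.4-fold lower number from compound 1 to compound 2 (0.53 log units; beyond the scatter), with benzyl replacing the acid hydrogen. It lies beyond the scatter and is at least modest. Compound 4, like compound 2, no longer carries the free carboxy group, so a modest move to a lower number is expected on the strength of an at least 3.4-fold lower number from compound 1 to compound 2 (0.53 log units; beyond the scatter), although a reading at the limit remains possible. The expected change is an at least 2.0-fold lower number from compound 1 to compound 4 (0.30 log units; that floor lies within the scatter). For compound 4 the estimate is 50000 nM, with an expected range of 20000 nM to 100000 nM.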

Compound 4, concentration for 50% growth inhibition: > 100000 nM
Compound 4: only a limit was reported; the forecaster's own chance of this, stated with the estimate: 45%; at least 2.0-fold (0.30 log units) between middle value and limit.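

Compound 1 and compound 4 both stand at a limit of this assay and not at a number, so the step between them cannot be read. The compounds shown leave open whether 2-hydroxyethyl in place of carboxy changes growth inhibition at all.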